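Methyl for Methoxy at Two Ring Positions

The source may hold more compounds than are shown below. What is called first, only, known or untested is meant among the compounds shown, and "the series" means these compounds.

Compound 1 `CCSC(=S)SCC(=O)c1ccc(C)cc1` gives 3980 nM in a functional assay on HeLa cells (Homo sapiens) for antiproliferative activity, read by resazurin assay; a higher number here means a weaker inhibitor, a lower number a stronger inhibitor. Compound 2 `CCSC(=S)SCC(=O)c1ccccc1OC` gives 15800 nM in this assay. Compound 3 `CCSC(=S)SCC(=O)c1ccc(OC)cc1` gives 2510 nM in this assay.

Compound 3 and compound 1 differ in one place, (methyl in place of methoxy on an aromatic carbon), and the step is a 1.6-fold higher number from compound 3 to compound 1 (0.20 log units; within the scatter). Compound 2 and compound 3 are built from the same atoms joined differently; the difference between the two cores is not broken down here. Compound 2 gives the highest number of the three. Compound 4 `CCSC(=S)SCC(=O)c1ccccc1C` has not been measured; it differs from compound 2 by methyl in place of methoxy on an aromatic carbon. This is the same kind of change as that between compound 3 and compound 1, but the place differs: here the methyl is ortho to a group of 9 heavy atoms, there it was para to a group of 9 heavy atoms. Because the earlier step was a 1.6-fold higher number from compound 3 to compound 1 (0.20 log units; within the scatter), a similarly small step is expected, a 1.1-fold higher number from compound 2 to compound 4 (0.06 log units; within the scatter). Compound 4 is therefore estimated at 18000 nM, likely between 6000 nM and 50000 nM.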

Compound 4, half-maximal inhibitory concentration: 10000 nM
Beside the measured number, compound 4's estimate is 1.8-fold (0.26 log units) above it; the measured number falls inside the stated range.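

In this assay, methyl in place of methoxy gives a 1.6-fold lower number from compound 2 to compound 4 (0.20 log units; within the scatter). Set beside the earlier case, this step and the gap between the two steps both lie within the scatter: the same change on two cores in this assay, a 1.6-fold higher number (0.20 log units; within the scatter) from compound 3 to compound 1 and a 1.6-fold lower number (0.20 log units; within the scatter) from compound 2 to compound 4, 2.5-fold (0.40 log units) apart, within the scatter of two such steps So the two pairs shown give no sign that this swap behaves differently on the two cores, but two pairs cannot show that it would carry over to every core in the series, nor that the swap is without effect.

The compounds shown leave open what an amine or a carboxylic acid would give on the aromatic ring in place of methyl or methoxy. They also leave open what a longer chain, such as ethoxy, would give at either place.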